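A few compounds are considered here, and "the series" means these few. Any claim that something is new, unique, unknown or untested is made for them only; others in the source may bear on it.

Within the data shown here, compound 1 `CCN(CCCCCCOc1ccc(C(=O)/C=C/c2ccc(N(C)C)cc2)c(O)c1)Cc1ccccc1` gives 2100 nM in an assay on isolated protein for inhibition of Amine oxidase [flavin-containing] B (Homo sapiens) (on this read-out higher numbers stand for weaker inhibition and lower numbers for stronger inhibition), the higher of the two numbers measured so far; its nearest neighbour is compound 2 `CCN(CCCCOc1ccc(C(=O)/C=C/c2ccc(N(C)C)cc2)c(O)c1)Cc1ccccc1OC`, which gives 1100 nM, and the step of a 1.9-fold lower number from compound 1 to compound 2 (0.28 log units; within the scatter) stays within the scatter. Compound 3 `CCN(CCCCCCOc1ccc(C(=O)/C=C/c2ccc(N(C)C)cc2)c(O)c1)Cc1ccc(N(C)C)cc1` carries the change (dimethylamino in place of hydrogen on an aromatic carbon). Among the measured compounds shown here, the only measured step alters the amine end and so bears little on this change; a step within the scatter is therefore expected, a 1.2-fold lower number from compound 1 to compound 3 (0.07 log units; within the scatter). Compound 3 is expected to give 1800 nM, between 700 nM and 4500 nM in this assay.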

Compound 3, half-maximal inhibitory concentration: 2300 nM
For compound 3 the middle estimate is 1.3-fold (0.11 log units) below the measured one, and the stated range covers the measured number.
By their numbers in this assay, from the lowest: compounds 2, 1 and 3 (each within the scatter of the next, the first and the last beyond it).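

In this assay, placing dimethylamino on the aromatic carbon para to a large group, which turns benzyl into 4-(dimethylamino)benzyl, gives a 1.1-fold higher number from compound 1 to compound 3 (0.04 log units; within the scatter) and so leaves the number within the scatter. Among these compounds, this is the first measured change on this ring at that position, and here a group of 3 heavy atoms replaces a hydrogen atom without a clear shift in the number. No measurement shown here gives a reason for this result. As far as these compounds go, whether a chlorine atom or a carboxylic acid at the same position would shift the number remains open.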